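This account rests on a few compounds, and the source may have more. Where it says the series, first, only, none or still open, it means among the compounds named here.

In an ADME assay (liver) for metabolic stability, with Liver microsome (Rattus norvegicus) as the target, read by LC-MS, using microsomes and NADPH, with stated times of 5 min and 60 min, tested at 4 uM (a lower number here means that less of the compound is left, a higher number that more of the compound is left), compound 2 `Cc1c(OCCCCOc2ccc(C(=O)O)cc2Cl)ccc(C(=O)CC(C)C)c1O` gives 61%. Going by the values given here, compound 1 `Cc1c(OCCCCOc2ccc(F)c(C(=O)O)c2)ccc(C(=O)CC(C)(C)C)c1O` gives 58% in this assay, a number that lies within the usual scatter of the one for compound 2, so the two cannot be told apart. Compound 3 `Cc1c(OCCCCOc2ccc(F)c(C(=O)O)c2)ccc(C(=O)CC(C)C)c1O` is not yet measured. It differs from compound 2 in one place: 3-carboxy-4-fluorophenyl in place of 4-carboxy-2-chlorophenyl on an oxygen on a saturated carbon. The 3-carboxy-4-fluorophenyl that enters is the group compound 1 already carries. Because compound 1 gives 58% in this assay, no step beyond the scatter is expected from compound 2 to compound 3, a number 2 percentage points lower from compound 2 to compound 3 (within the scatter). Compound 3 is estimated at 59%, between 45% and 72%.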

Compound 3, percent of the compound remaining: 59%
Beside the measured number, compound 3's estimate shows no gap at the digits printed; low and high end bracket the measured number.
By their numbers in this assay, from the lowest: compounds 1, 3 and 2 (each within the scatter of the next).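

In this assay, 3-carboxy-4-fluorophenyl in place of 4-carboxy-2-chlorophenyl on an oxygen on a saturated carbon gives a number 2 percentage points lower from compound 2 to compound 3 (within the scatter), so these two groups cannot be told apart at this position. Hydrogen in place of methyl on a saturated chain carbon bound to three saturated chain carbons gives a number 1 percentage points higher from compound 1 to compound 3 (within the scatter), so that change cannot be read as a difference either. Nothing available gives a reason for either result. From the compounds shown here alone, it remains open whether an amide or a tetrazole in place of the carboxy group would give a step beyond the scatter in this assay.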